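Swapping the aryl group on a ring amine

This account rests on a few compounds, and the source may have more. Where it says the series, first, only, none or still open, it means among the compounds named here.

Of the compounds shown here, three that share one core have been tested in a functional assay on HeLa cells (Homo sapiens) for antiproliferative activity, read by CCK-8 assay, with a stated time of 72 h, tested at 2 uM; on this read-out lower numbers stand for a weaker effect and higher numbers for a stronger effect at the one concentration tested. Compound 1 `N#Cc1ccc(N2CCN(C(=S)SCc3ccc(C(=O)Nc4ccccc4N)cc3)CC2)cc1` gives 71.6%, the highest of the three numbers. Compound 2 `CC1CCN(C(=S)SCc2ccc(C(=O)Nc3ccccc3N)cc2)CC1` gives 46.8%, a number well below that of compound 1, beyond the usual scatter. Compound 3 `Nc1ccccc1NC(=O)c1ccc(CSC(=S)N(Cc2ccccc2)Cc2ccccc2)cc1` gives 1%, the lowest of the set and far below compound 1. Within the data shown here, compound 2 and compound 3 lack the aryl-bearing ring amine of compound 1, and their numbers fall with that change, but with only three compounds no firm pattern can be claimed.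

Compound 4 `Nc1ccccc1NC(=O)c1ccc(CSC(=S)N2CCN(c3ccccc3F)CC2)cc1` has not yet been measured. It differs from compound 1 in one place: 2-fluorophenyl in place of 4-cyanophenyl on an amine nitrogen in a ring. Since compound 4 keeps the ring amine that carries an aryl group, as in compound 1, a number nearer to compound 1 than to compound 3 is expected. Still, the group that enters is not the group that leaves, so a modest drop is estimated, with the step from compound 1 to compound 4 in this assay expected at a number 13.6 percentage points lower from compound 1 to compound 4 (beyond the scatter), roughly at the edge of the scatter. For compound 4 the expected value in this assay is 58%, with a range from 35% to 75%.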

Compound 4, a percentage reported as inhibition, at one concentration (the size of the read-out at that concentration, not a potency): 17.5%
Estimate against measurement, compound 4: 40.5 percentage points above; the measured number lies below the stated range.
By their numbers in this assay, from the lowest: compound 3; then compound 4; then compound 2; then compound 1.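

In this assay, the aryl-bearing ring amine alone does not secure a high number: 2-fluorophenyl in place of 4-cyanophenyl gives a number 54.1 percentage points lower from compound 1 to compound 4 (beyond the scatter). Among these compounds, both groups hold a six-membered aromatic ring of carbon only on the same amine nitrogen, so this position responds strongly to what that ring carries and to where it carries it, a sensitivity that the earlier compounds, with their differing amine parts, could not reveal. No measurement shown here explains why this swap costs so much.

The step also changes two things at once, the nitrile becoming fluorine and the substituent's place on the phenyl ring moving, and the compounds shown cannot tell which of these matters, or whether both do. A 4-fluorophenyl or 2-cyanophenyl group on this nitrogen would pull the two apart, while an unsubstituted phenyl group would show what the substituents add to the bare ring, and a 4-methoxyphenyl group would test whether the nitrile itself is needed at that place.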